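Acylguanidine series: shortening the ring substituent of compound 2

A few compounds are considered here, and "the series" means these few. Any claim that something is new, unique, unknown or untested is made for them only; others in the source may bear on it.

Measured so far:
compound 1 `Cc1cc2c(cc1C(=O)N=C(N)N)S(=O)(=O)CCC2`: 95 nM
compound 2 `CCC1(O)CS(=O)(=O)c2cc(C(=O)N=C(N)N)c(C)cc21`: 34 nM

In an assay on cells for inhibition of sodium/hydrogen exchanger (Oryctolagus cuniculus) (on this read-out higher numbers stand for weaker inhibition and lower numbers for stronger inhibition), compound 1 gives 95 nM, whereas compound 2 gives 34 nM in this assay. Compound 2 therefore stands at the lower of the two numbers, and the gap to compound 1 lies beyond the scatter, so compound 2 is the stronger inhibitor of the two that have been measured.

Compound 3 `Cc1cc2c(cc1C(=O)N=C(N)N)S(=O)(=O)CC2(C)O` has not yet been measured. It differs from compound 2 in one place: hydrogen in place of methyl on a saturated chain carbon bound to a saturated ring carbon. The core and the acylguanidine are kept, as is the hydroxyl on the saturated ring carbon.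

Among the measured compounds shown here, no pair of measured compounds shows the effect of this kind of change, so there is no basis for a large step in this assay in either direction. The expectation for compound 3 is a number close to that of compound 2, with a step of a 1.3-fold higher number from compound 2 to compound 3 (0.12 log units; within the scatter) that is estimated to stay within the scatter, leaning if anything towards a slightly higher number. For compound 3 the estimate in this assay is 45 nM, with a range from 20 nM to 110 nM.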

Compound 3, half-maximal inhibitory concentration: 30 nM
Estimate against measurement, compound 3: 1.5-fold (0.18 log units) above; the measured number falls inside the stated range.
By their numbers in this assay, from the lowest: compounds 3 and 2 (each within the scatter of the next); then compound 1.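

In this assay, among the compounds shown here, the change from ethyl to methyl, hydrogen in place of methyl on a saturated chain carbon bound to a saturated ring carbon, gives a 1.1-fold lower number from compound 2 to compound 3 (0.05 log units; within the scatter) and is the first one-place comparison. On this read-out the two chain lengths cannot be told apart, so at this position, with the hydroxyl, the core and the acylguanidine kept, the ethyl and the methyl serve alike; this holds for this single pair only. Nothing available bears on why the two compounds read alike, and no explanation can be offered from the data in hand.

Whether the same holds further out is open: a longer chain such as butyl, a phenyl, or an amine or a carboxylic acid at the end of the chain could read quite differently in this assay and would show how much room this position has. The part played by the hydroxyl also stays open, as no pair shown changes it alone, and a methoxy in its place would address that.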